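Methyl in Place of Hydrogen: From Compound 1 to Compound 3

A few compounds are considered here, and "the series" means these few. Any claim that something is new, unique, unknown or untested is made for them only; others in the source may bear on it.

Compound 1 `CCc1ccc2[nH]c(=O)c(CN(Cc3ccc(F)cc3)Cc3ccc(C(C)(C)C)cc3)cc2c1` carries a tert-butyl group and a 4-fluorobenzyl group on its shared core. In a toxicity assay on MDCK cells (Canis lupus familiaris) for cytotoxicity, read by crystal violet staining, with a stated time of 48 h (a lower number here means that less compound is tolerated, a higher number that more compound is tolerated), compound 1 gives > 33000 nM, which is a limit of the assay rather than a number. Compound 2 `CCc1ccc2[nH]c(=O)c(CN(Cc3ccc(F)cc3)Cc3ccc(-c4ccccc4)cc3)cc2c1` has phenyl in place of tert-butyl on an aromatic carbon. In this assay compound 2 gives > 5000 nM, again a limit. The step that the two limits leave unreadable from compound 1 to compound 2 is therefore unreadable, both values sitting at limits (the limit of > 33000 nM in this assay, at which 1 of the 2 values shown sits, and (the limit of > 5000 nM in this assay, at which 1 of the 2 values shown sits)). Compound 3 `CCc1ccc2[nH]c(=O)c(CN(Cc3ccc(C(C)(C)C)cc3)[C@H](C)c3ccc(F)cc3)cc2c1` differs from compound 1 by methyl in place of hydrogen on a saturated chain carbon bound to an amine nitrogen and an aromatic carbon. Within the data shown here, no measured step touches this change, so no direction can be drawn from the two measured compounds. Compound 3 is thus expected to show no step beyond the scatter, with a number no higher from compound 1 to compound 3 (the limit leaves the size open) as the estimated step. Compound 3 is estimated at 33000 nM, within 10000 nM to 100000 nM, most likely again as a limit.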

Compound 3, half-maximal cytotoxic concentration: > 5000 nM
Compound 3 gave a limit, no number; the forecaster's own chance of this, stated with the estimate: 70%; the middle value is on the limit's open side.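

In this assay compound 3 gives > 5000 nM, a limit of the assay and not a number, and compound 1 also stands at a limit, so the step between compound 1 and compound 3 cannot be read. The compounds shown leave open whether 1-(4-fluorophenyl)ethyl in place of 4-fluorobenzyl changes how much compound is tolerated.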